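A few compounds are considered here, and "the series" means these few. Any claim that something is new, unique, unknown or untested is made for them only; others in the source may bear on it.

Series notes, two measured members and one open. Compound 1 `Cc1ccc(CNC(=O)c2nn(-c3ccc(F)cc3)c(CC[C@@H](O)C[C@@H](O)CC(=O)O)c2C(C)C)cc1` gives 2.5 nM in an assay on microsomes from liver for inhibition of 3-hydroxy-3-methylglutaryl-coenzyme A reductase (Rattus norvegicus); a higher number here means a weaker inhibitor, a lower number a stronger inhibitor. Compound 2 `Cc1ccc(CN(C)C(=O)c2nn(-c3ccc(F)cc3)c(OC[C@@H](O)C[C@@H](O)CC(=O)O)c2C(C)C)cc1` gives 37 nM in this assay, the higher of the two numbers, and the gap to compound 1 lies beyond the scatter; compound 1 and compound 2 differ in more than one place, so no single change can be read from that pair.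

Compound 3 `COc1ccc(CNC(=O)c2nn(-c3ccc(F)cc3)c(OC[C@@H](O)C[C@@H](O)CC(=O)O)c2C(C)C)cc1` is the next step: (4-methoxybenzyl)amino in place of methyl(4-methylbenzyl)amino on a carbonyl carbon, the rest of compound 2 kept. Within the data shown here, no measured step isolates this change. Compound 1, which carries a secondary amide, stands at 2.5 nM, and on that basis the step from compound 2 to compound 3 is expected to move the number down, estimated at a 4.6-fold lower number from compound 2 to compound 3 (0.67 log units; beyond the scatter), more than the scatter. Compound 3 is therefore estimated at 8 nM in this assay, with a range from 2.5 nM to 25 nM.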

Compound 3, half-maximal inhibitory concentration: 12 nM
Compound 3: middle estimate off by 1.5-fold (0.18 log units), on the low side, within the range that was stated.
By their numbers in this assay, from the lowest: compound 1; then compound 3; then compound 2.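

In this assay the carbonyl carbon gives its first readable single-place step: (4-methoxybenzyl)amino in place of methyl(4-methylbenzyl)amino gives a 3.1-fold lower number from compound 2 to compound 3 (0.49 log units; beyond the scatter) at this position, so the group here affects the number even with the rest of compound 2 kept. The entering group has a hydrogen-bond donor and a hydrogen-bond acceptor that the leaving group lacks, at the same heavy-atom count, but this one step changes the amide nitrogen and the group at the 4-position of the benzyl together. No measurement at hand explains the lower number.

From the compounds shown here alone, how the step divides between loss of the methyl on the amide nitrogen and the change from methyl to methoxy remains open. Methyl(4-methoxybenzyl)amino on the same carbonyl carbon, with the rest of compound 3 kept, would separate the two.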